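Sulfonyl substituent exchange on compound 1: benzyl to sulfamoyl

The compounds below may be only part of what the source reports. "The series", "measured", "known", "first", "only" and "open" are said of these compounds alone.

Three compounds carry a measurement in an assay on CHO cells for displacement of a labelled ligand from prostaglandin D2 receptor 2 (Homo sapiens), read by scintillation counting; on this read-out lower numbers stand for stronger inhibition and higher numbers for weaker inhibition. Compound 1 `Cc1ccc(S(=O)(=O)Cc2ccccc2)cc1C#Cc1cc(Cl)ccc1OCC(=O)O` gives 5 nM in this assay, the highest of the three numbers. Compound 3 `CS(=O)(=O)c1ccc(F)c(C#Cc2cc(Cl)ccc2OCC(=O)O)c1` gives 3.3 nM, which sits within the scatter of the number for compound 1, so the two cannot be told apart. Compound 2 `CCCS(=O)(=O)c1ccc(C)c(C#Cc2cc(Cl)ccc2OC(C)C(=O)O)c1` gives 1.2 nM, a number that lies beyond the scatter below compound 1, and this is the only separation among the three that can be trusted. No pair of these compounds differs in a single place, so no step between measured compounds is available.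

Compound 4 `Cc1ccc(S(=O)(=O)N(C)CC(C)C)cc1C#Cc1cc(Cl)ccc1OCC(=O)O` is the unmeasured member. It differs from compound 1 in one place: isobutyl(methyl)amino in place of benzyl on a sulfonyl sulfur. The sulfonyl sulfur keeps its aromatic carbon neighbour, and the rest of the core of compound 1 is unchanged.

Nothing measured here speaks directly to this exchange, and the three numbers cover only a narrow span. The step from compound 1 to compound 4 is therefore expected to be small, with no confident direction and quite possibly none beyond the scatter. Compound 4 is estimated at 6 nM in this assay, with the expected range running from 1.5 nM to 25 nM, the expected step being a 1.2-fold higher number from compound 1 to compound 4 (0.08 log units; within the scatter).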

Compound 4, inhibition constant: 4.2 nM
Estimate against measurement, compound 4: 1.4-fold (0.15 log units) above; the measured number falls inside the stated range.
By their numbers in this assay, from the lowest: compound 2; then compounds 3, 4 and 1 (each within the scatter of the next).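

In this assay, isobutyl(methyl)amino in place of benzyl on a sulfonyl sulfur gives a 1.2-fold lower number from compound 1 to compound 4 (0.08 log units; within the scatter), the first single-place step available in this series. The benzylsulfonyl and isobutyl(methyl)sulfamoyl forms cannot be told apart here, so at this position the six-membered aromatic ring of carbon can leave and an open-chain group carrying nitrogen can enter, with the core of compound 1 unchanged, without a change that can be read beyond the scatter. No measurement shown bears on why these two groups read alike.

Among the compounds shown here, this single step covers only one pair of groups on the sulfonyl sulfur, so it sets no general rule for the position. As far as these compounds go, it remains open whether a ring-bearing amine such as piperidine or morpholine, an unsubstituted amino group, or a longer chain carrying a carboxylic acid would also stay within the scatter of compound 1 when placed on that sulfur.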